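Notes toward compound 4: 2-chlorophenyl for 3-fluorophenyl

The source may hold more compounds than are shown below. What is called first, only, known or untested is meant among the compounds shown, and "the series" means these compounds.

Of the compounds shown here, three have been measured in a functional assay on the whole organism (strain Swiss) with Mus musculus as the target, in the maximal electroshock model, with a stated time of 0.25 h, at a dose of 300 mg/kg by the intraperitoneal route; a lower number here means a weaker effect, a higher number a stronger effect of the compound at the dose given. Compound 2 `CCC(C(=O)N1CCN(c2cccc(F)c2)CC1)N1C(=O)CCC1=O` gives 75%. Compound 1 `CCC(C(=O)N1CCN(c2ccccc2Cl)CC1)N1C(=O)CCC1=O` gives 50% in this assay. Compound 3 `CC(C(=O)N1CCN(c2cccc(F)c2)CC1)N1C(=O)CCC1=O` gives 100% in this assay, the highest of the three numbers. The step from compound 2 to compound 1 is a number 25 percentage points lower from compound 2 to compound 1 (beyond the scatter); the structural difference behind it is 2-chlorophenyl in place of 3-fluorophenyl on an amine nitrogen in a ring. The step from compound 2 to compound 3 is a number 25 percentage points higher from compound 2 to compound 3 (beyond the scatter); that difference, (hydrogen in place of methyl on a saturated chain carbon, two bonds along the chain from an amide-type nitrogen in a ring and a carbonyl carbon), is also how the core of compound 3 differs from the core of compound 2, so compound 3 and compound 4 stand on the other core.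

Compound 4 `CC(C(=O)N1CCN(c2ccccc2Cl)CC1)N1C(=O)CCC1=O` has not yet been measured in this assay. It differs from compound 3 by 2-chlorophenyl in place of 3-fluorophenyl on an amine nitrogen in a ring. The same change occurs twice among these compounds, from compound 2 to compound 1 and from compound 3 to compound 4, and the place of the change reads the same in both, so it is the same change carried onto the other core. For the measured compounds named here, for compound 4 the expected step is a number 25 percentage points lower from compound 3 to compound 4 (beyond the scatter), which rests on the single earlier instance, because a number 25 percentage points lower from compound 2 to compound 1 (beyond the scatter). The read-out cannot rise above its ceiling, so the true effect of compound 3 may be larger than its number shows, which widens the range for compound 4 upward. Compound 4 is estimated at 75%, expected to fall between 50% and 100%.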

Compound 4, a percentage reported as activity, at one dose (the size of the read-out at that dose, not a potency): 0%
The estimate for compound 4 lay 75 percentage points above the measured number; measured number below the stated range.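

Carried onto the other core in this assay, 2-chlorophenyl in place of 3-fluorophenyl gives a number 100 percentage points lower from compound 3 to compound 4 (beyond the scatter), so the direction of the step holds on both cores but its size does not: the same change on two cores in this assay, a number 25 percentage points lower (beyond the scatter) from compound 2 to compound 1 and a number 100 percentage points lower (beyond the scatter) from compound 3 to compound 4, 75 percentage points apart, beyond the scatter of two such steps
Hydrogen in place of methyl on the saturated chain carbon gives a number 50 percentage points lower from compound 1 to compound 4 (beyond the scatter), so the direction of this change reverses between the 3-fluorophenyl and 2-chlorophenyl compounds and the two changes do not add up across these four compounds: the same change on two cores in this assay, a number 25 percentage points higher (beyond the scatter) from compound 2 to compound 3 and a number 50 percentage points lower (beyond the scatter) from compound 1 to compound 4, 75 percentage points apart, beyond the scatter of two such steps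
This shows that neither step can be carried from one core to another in this series as a fixed increment, but it does not show why, and it does not give the true size of the gap, since compound 3 and compound 4 stand at the two ends of the percentage scale at a single dose and a single time, and the halogen and its place on the ring change together.

On these data alone, it remains open whether the sharp loss belongs to chlorine, to its place on the ring, or to both, which 3-chlorophenyl and 2-fluorophenyl on each core would help to separate. Also open, as far as these compounds go, is how an unsubstituted phenyl or a longer chain on the saturated carbon would behave on these cores.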